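A few compounds are considered here, and "the series" means these few. Any claim that something is new, unique, unknown or untested is made for them only; others in the source may bear on it.

Measured so far:
- Compound 1 `Nc1sc2c(c1-c1nc3cc(Cl)ccc3s1)CCC2`: 59.1 ug/mL
- Compound 2 `Nc1sc2c(c1-c1nc3cc(Cl)ccc3s1)CCCC2`: 43.5 ug/mL
- Compound 3 `Fc1ccccc1/C=N/c1sc2c(c1-c1nc3ccccc3s1)CCC2`: 270 ug/mL

In an ADME assay on cells (Rhabdomyosarcoma cell, Homo sapiens) for cytotoxicity, read by MTT assay, with a stated time of 72 h (on this read-out higher numbers stand for lower toxicity in this test and lower numbers for higher toxicity in this test), compound 3 gives 270 ug/mL, the highest of the three numbers; compound 1 is nearer and compound 2 further, and both gaps lie beyond the scatter of repeated runs.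

Compound 4 `C(=C/c1ccccc1)\C=N\c1sc2c(c1-c1nc3ccccc3s1)CCC2` has not been measured. It differs from compound 3 in one place: 2-phenylethenyl in place of 2-fluorophenyl on a carbon with a double bond to nitrogen. For the measured compounds named here, no pair of measured compounds shows what a change of this kind does, so there is no step to lean on. With the rest of the structure kept, a step near the scatter is expected, if anything toward a slightly lower number.

The step from compound 3 to compound 4 is thus expected to be a 1.4-fold lower number from compound 3 to compound 4 (0.13 log units; within the scatter), giving compound 4 an estimated 200 ug/mL, within a range of 80 ug/mL to 500 ug/mL.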

Compound 4, half-maximal cytotoxic concentration: 122 ug/mL
Beside the measured number, compound 4's estimate is 1.6-fold (0.21 log units) above it; measured number inside the range.
By their numbers in this assay, from the lowest: compounds 2 and 1 (each within the scatter of the next); then compound 4; then compound 3.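

In this assay the group on a carbon with a double bond to nitrogen matters: 2-phenylethenyl in place of 2-fluorophenyl gives a 2.2-fold lower number from compound 3 to compound 4 (0.35 log units; beyond the scatter) and so a modest shift toward higher toxicity in this test. Both groups hold one six-membered aromatic ring of carbon only, so a change that keeps such a ring can still move the number beyond the scatter. No measurement here gives a reason for this step.

On these data alone, whether losing the fluorine or gaining the extra double bond matters more stays open, as does what an amine or a carboxylic acid would do at this place.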